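Compound 2 to compound 4: a but-3-en-1-yl swap

The source may hold more compounds than are shown below. What is called first, only, known or untested is meant among the compounds shown, and "the series" means these compounds.

In a functional assay on FM3A cells (Mus musculus) for cytotoxicity (a higher number here means that more compound is needed for the effect, a lower number that less compound is needed), compound 1 `COOC1(OOC)CCCCCCCCCCC1` gives 1500 nM. Compound 2 `COOC1(OOC(C)(C)OC)CCCCCCCCCCC1` gives 7300 nM and sits at the high end of the numbers, level within the scatter with compound 3 `COOC1(OOCCCCCCOC2CCOCC2)CCCCCCCCCCC1` at 7600 nM.

Compound 4 `C=CCCOOC1(OOC)CCCCCCCCCCC1` is reached from compound 2 by putting but-3-en-1-yl in place of 1-methoxy-1-methylethyl on an oxygen. Among the compounds with values here, no measured compound carries but-3-en-1-yl. Within the data shown here, the one measured step that bears on this change is a 4.9-fold higher number from compound 1 to compound 2 (0.69 log units; beyond the scatter), which is modest and beyond the scatter, and it introduced the group that now leaves. Compound 4 may therefore give back part of that rise. Compound 3 at 7600 nM also lacks 1-methoxy-1-methylethyl, which argues against expecting a full return.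

The expected change is small, toward a lower number and not beyond the scatter: a 1.8-fold lower number from compound 2 to compound 4 (0.26 log units; within the scatter). For compound 4 the estimated value is 4000 nM, with an expected range from 1500 nM to 10000 nM.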

Compound 4, half-maximal effective concentration: 6000 nM
For compound 4 the middle estimate is 1.5-fold (0.18 log units) below the measured one; measured number inside the range.
By their numbers in this assay, from the lowest: compound 1; then compounds 4, 2 and 3 (each within the scatter of the next).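

On this oxygen, in this assay, the change to but-3-en-1-yl, which counts no hydrogen-bond acceptor, gives a 1.2-fold lower number from compound 2 to compound 4 (0.09 log units; within the scatter), so the high numbers do not depend on 1-methoxy-1-methylethyl or its acceptor. With allyl in place of hydrogen on a saturated chain carbon bound to an oxygen on an unsaturated carbon, the series shows a 4.0-fold higher number from compound 1 to compound 4 (0.60 log units; beyond the scatter), a second rise of modest size alongside a 4.9-fold higher number from compound 1 to compound 2 (0.69 log units; beyond the scatter), so two different replacements for the methyl of compound 1 both end at higher numbers. Nothing available accounts for this rise.

Still open, as far as these compounds go, is whether ethyl on this oxygen stays level with compound 1 or already reaches the higher numbers. From the compounds shown here alone, it is also open whether a chain carrying an amine or a carboxylic acid on the same oxygen would depart from this level.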